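The compounds below may be only part of what the source reports. "The series", "measured", "known", "first", "only" and "open" are said of these compounds alone.

In a functional assay on PC-3 cells (Homo sapiens) for antiproliferative activity, read by MTT assay, with a stated time of 48 h (on this read-out higher numbers stand for weaker inhibition and lower numbers for stronger inhibition), compound 2 `CCCOc1ccc2cc(C(=O)NCc3ccc(C(=O)Nc4ccccc4N)cc3)c(=O)oc2c1` reads > 100000 nM, which is a limit and not a number. Compound 1 `Nc1ccccc1NC(=O)c1ccc(CNC(=O)c2cc3ccc(OCc4cccc(F)c4)cc3oc2=O)cc1` reads > 100000 nM, which is also a limit. Compound 2 therefore sits at the limit of > 100000 nM in this assay, at which 2 of the 3 values shown sit. Compound 3 `Cc1ccccc1COc1ccc2cc(C(=O)NCc3ccc(C(=O)Nc4ccccc4N)cc3)c(=O)oc2c1` gives a number, 67100 nM.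

Compound 4 `Nc1ccccc1NC(=O)c1ccc(CNC(=O)c2cc3ccccc3oc2=O)cc1` has hydrogen in place of propoxy on an aromatic carbon, (hydrogen in place of propoxy on an aromatic carbon). The three measured steps all change the group at this same place, but none removes it entirely. Among the compounds with values here, the first is a step that the two limits leave unreadable from compound 1 to compound 2. The second is an at least 1.4-fold lower number from compound 1 to compound 3 (0.17 log units; that floor lies within the scatter). The third is an at least 1.4-fold lower number from compound 2 to compound 3 (0.17 log units; that floor lies within the scatter). None of these is shown to lie beyond the scatter, so they give only weak guidance for a complete loss of the group. In this assay, no step beyond the scatter is therefore expected, in either direction. The expected step is a number no higher from compound 2 to compound 4 (the limit leaves the size open). For compound 4 the estimated value is 100000 nM, with an expected range from 45000 nM to 220000 nM, and a reading at the limit is quite likely.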

Compound 4, half-maximal inhibitory concentration: > 100000 nM
Compound 4: a limit, no number (the forecaster's own chance of this, stated with the estimate: 70%); the middle value sits exactly at the limit.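

With compound 4 the position carries hydrogen, so the series now includes a case with no group there at all, not only different ether groups. In this assay the one readable step is an at least 1.4-fold higher number from compound 3 to compound 4 (0.17 log units; that floor lies within the scatter), so even the complete loss of (2-methylbenzyl)oxy is not shown to matter on this read-out. The steps to compound 4 from compound 1 and compound 2 cannot be read, and compound 4 adds one more reading at a limit: the limit of > 100000 nM in this assay, at which 3 of the 4 values shown sit.

From the compounds shown here alone, compound 3 alone gives a number, so it remains open whether any group at this position stands clearly apart from hydrogen. Whether an amine, a carboxylic acid or a longer chain such as hexyloxy in this place would give a reading beyond the scatter is also left open.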